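The source may hold more compounds than are shown below. What is called first, only, known or untested is meant among the compounds shown, and "the series" means these compounds.

In an assay for inhibition of Thromboxane-A synthase (Homo sapiens), using microsomes (a lower number here means a stronger inhibitor, a higher number a weaker inhibitor), compound 1 `CC(C)(Oc1ccccc1O)C1OCC(C/C=C\CCC(=O)O)C(c2cccnc2)O1` gives 32 nM and compound 2 `CC(C)(Cc1ccc(F)cc1)C1OCC(C/C=C\CCC(=O)O)C(c2cccnc2)O1` gives 45 nM, the step of a 1.4-fold higher number from compound 1 to compound 2 (0.15 log units; within the scatter) being a swap of the side group. Among the measured compounds shown here, compound 2 therefore stands within the scatter of compound 1, the only other compound measured. Compound 3 `CC(C)(Cc1ccc(F)cc1C#N)C1OCC(C/C=C\CCC(=O)O)C(c2cccnc2)O1` differs from compound 2 by cyano in place of hydrogen on an aromatic carbon. For the measured compounds named here, no measured step touches that aromatic position; the only step known, a 1.4-fold higher number from compound 1 to compound 2 (0.15 log units; within the scatter), exchanged the whole side group and stayed within the scatter. Compound 3 is accordingly expected to show no step beyond the scatter, a 1.1-fold lower number from compound 2 to compound 3 (0.05 log units; within the scatter). Compound 3 is estimated at 40 nM, between 15 nM and 120 nM.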

Compound 3, half-maximal inhibitory concentration: < 10 nM
Compound 3: only a limit was reported; the forecaster's own chance of this, stated with the estimate: 3%; middle value at least 4.0-fold (0.60 log units) away from the limit.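

In this assay, cyano in place of hydrogen on the aromatic carbon ortho to a large group and meta to a fluoro group gives an at least 4.5-fold lower number from compound 2 to compound 3 (0.65 log units; beyond the scatter) and so moves the number beyond the scatter. The exchange of the whole side group, within the scatter in a 1.4-fold higher number from compound 1 to compound 2 (0.15 log units; within the scatter), now reads as an at least 3.2-fold lower number from compound 1 to compound 3 (0.50 log units; beyond the scatter) once this cyano is present. The value of compound 3 is a limit and not a number, so both new steps give only a smallest size: the limit of < 10 nM in this assay, at which 1 of the 3 values shown sits.

On these data alone, how far compound 3 lies past that limit stays open. So does whether a methyl, a chlorine or an amine on the same aromatic carbon would give a step of this size.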